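Replacing pyrrolidin-1-yl with benzyl(methyl)amino in compound 3

This account rests on a few compounds, and the source may have more. Where it says the series, first, only, none or still open, it means among the compounds named here.

In a functional assay on MCF7 cells (Homo sapiens) for antiproliferative activity, read by MTT assay, with a stated time of 24 h (on this read-out lower numbers stand for stronger inhibition and higher numbers for weaker inhibition), compound 1 `CCCCc1oc2ccccc2c1C(=O)c1ccc(OCC(=O)N2CCCCC2)cc1` gives > 50000 nM as a limit of the assay. Compound 2 `CCCCc1oc2ccccc2c1C(=O)c1ccc(OCC(=O)N2CCOCC2)cc1` gives 34000 nM and compound 3 `CCCCc1oc2ccccc2c1C(=O)c1ccc(OCCCC(=O)N2CCCC2)cc1` gives 23500 nM within the scatter of compound 2. Compound 4 `CCCCc1oc2ccccc2c1C(=O)c1ccc(OCCCC(=O)N(C)Cc2ccccc2)cc1` has benzyl(methyl)amino in place of pyrrolidin-1-yl on a carbonyl carbon and remains unmeasured. Among the compounds with values here, no measured step makes this exact change. The nearest swap on a carbonyl carbon gave an at least 1.4-fold lower number from compound 1 to compound 2 (0.16 log units; that floor lies within the scatter) and the changes that also altered the chain gave a 1.4-fold lower number from compound 2 to compound 3 (0.16 log units; within the scatter) and an at least 2.1-fold lower number from compound 1 to compound 3 (0.32 log units; beyond the scatter) as well. The estimated step is a 1.2-fold lower number from compound 3 to compound 4 (0.07 log units; within the scatter) with nothing beyond the scatter expected. For compound 4 an estimated 20000 nM is expected in this assay with a range of 7000 nM to 50000 nM around it.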

Compound 4, half-maximal inhibitory concentration: > 50000 nM
Compound 4: a limit, no number (the forecaster's own chance of this, stated with the estimate: 20%); at least 2.5-fold (0.39 log units) between middle value and limit.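

With the chain held as in compound 3, benzyl(methyl)amino in place of pyrrolidin-1-yl on a carbonyl carbon weakens the effect in this assay and gives an at least 2.1-fold higher number from compound 3 to compound 4 (0.32 log units; beyond the scatter) on this read-out. Within the data shown here, this is the first single swap at this position whose step passes the scatter. The step is only a floor, since compound 4 sits at a limit of the assay: the limit of > 50000 nM in this assay, at which 2 of the 4 values shown sit.

The compounds shown leave open how a dimethylamino group or an open-chain amide with the amide hydrogen would read here. They also leave open whether a longer chain would keep the value of compound 3.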